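The compounds below may be only part of what the source reports. "The series", "measured", "known", "first", "only" and "open" are said of these compounds alone.

In an ADME assay on HUVEC cells (Homo sapiens) for cytotoxicity, read by MTT assay, with a stated time of 24 h (a higher number here means a weaker inhibitor, a lower number a stronger inhibitor), compound 1 (`C[C@H]1O[C@]1(C)C(=O)C[C@@H]1[C@@]2(C)[C@@H](O)CCC(C)(C)[C@]2(O)CC[C@@]1(C)O`) gives > 10000 nM, which is a limit of the assay and not a number. Compound 2 (`C[C@H]1O[C@]1(C)C(=O)C[C@H]1[C@](C)(O)CC[C@@]2(O)C(C)(C)CCC[C@]12C`) gives > 10000 nM, which is also only a limit. Going by the values given here, the one measured step, a step that the two limits leave unreadable from compound 1 to compound 2, therefore gives no size to build on, and it is a different change from the one that follows. Compound 3 (`C/C=C(\C)C(=O)C[C@H]1[C@](C)(O)CC[C@@]2(O)C(C)(C)CCC[C@]12C`) carries 1-methylprop-1-en-1-yl in place of 2,3-dimethyloxiran-2-yl on a carbonyl carbon. Among the compounds with values here, no measured step covers this swap, so any forecast is weak. Compound 3 is expected to remain weak in this assay, with no step beyond the scatter, because of the limit of > 10000 nM in this assay, at which 2 of the 2 values shown sit, which includes compound 2. The expected step is a step that the limit leaves unreadable from compound 2 to compound 3. For compound 3 the estimated value is 20000 nM, with an expected range from 10000 nM to 60000 nM.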

Compound 3, half-maximal inhibitory concentration: > 10000 nM
Compound 3 ended at the assay's limit; the forecaster's own chance of this, stated with the estimate: 85%; the middle value is on the limit's open side.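

No step can be read from compound 2 to compound 3, since each gives only a limit and not a number in this assay: the limit of > 10000 nM in this assay, at which 3 of the 3 values shown sit. The compounds shown leave open how strongly any of them acts in this assay, and whether 1-methylprop-1-en-1-yl in place of 2,3-dimethyloxiran-2-yl changes that at all.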